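A few compounds are considered here, and "the series" means these few. Any claim that something is new, unique, unknown or untested is made for them only; others in the source may bear on it.

Of the compounds shown here, three sharing one core have been measured in a functional assay on HeLa cells (Homo sapiens) for inhibition, read by sulforhodamine B assay (on this read-out higher numbers stand for weaker inhibition and lower numbers for stronger inhibition), and they differ only in the group on the amine nitrogen. Compound 1 `O=C1C(NC2CCCC2)=CC(=O)c2c1nc1n2[C@H]2OC[C@@H](O)[C@H]2OC1`, which carries cyclopentyl, reports only a limit, > 16000 nM. Compound 3 `O=C1C(NC2CC2)=CC(=O)c2c1nc1n2[C@H]2OC[C@@H](O)[C@H]2OC1`, which carries cyclopropyl, also reports only a limit, > 16000 nM. Both therefore stand at the limit of > 16000 nM in this assay, at which 2 of the 3 values shown sit, and there is a step that the two limits leave unreadable from compound 1 to compound 3. Compound 2 `O=C1C(Nc2ccc(Br)cc2)=CC(=O)c2c1nc1n2[C@H]2OC[C@@H](O)[C@H]2OC1`, which carries 4-bromophenyl, is the only one of the three with a number, 5220 nM. The measured steps are an at least 3.0-fold lower number from compound 1 to compound 2 (0.48 log units; beyond the scatter) and an at least 3.0-fold higher number from compound 2 to compound 3 (0.48 log units; beyond the scatter).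

Compound 4 `CCOc1ccccc1NC1=CC(=O)c2c(nc3n2[C@H]2OC[C@@H](O)[C@H]2OC3)C1=O` follows from compound 3 by one change: 2-ethoxyphenyl in place of cyclopropyl on an amine nitrogen, with 2-ethoxyphenyl in place of cyclopropyl on an amine nitrogen. Among the measured compounds shown here, its closest guide is compound 2, the only aromatic example, since an at least 3.0-fold higher number from compound 2 to compound 3 (0.48 log units; beyond the scatter) is the same kind of exchange run in the opposite direction. However, that guide rests on a single compound with a different substituent on the aromatic ring, so the size remains uncertain, and a further limit is possible. A modest move towards a lower number is expected in this assay, and the estimated step is an at least 2.2-fold lower number from compound 3 to compound 4 (0.35 log units; beyond the scatter). For compound 4 the estimated value is 7000 nM, with an expected range from 2500 nM to 16000 nM.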

Compound 4, half-maximal inhibitory concentration: 8300 nM
Compound 4: middle estimate off by 1.2-fold (0.07 log units), on the low side; the range from low to high includes it.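

In this assay, compound 4 shows that a second aromatic group on the amine nitrogen also gives a measured number, so the readable result at this position no longer rests on the 4-bromophenyl of compound 2 alone. Exchanging 4-bromophenyl for 2-ethoxyphenyl gives a 1.6-fold higher number from compound 2 to compound 4 (0.20 log units; within the scatter), so these two aromatic groups cannot be told apart here even though their substituents differ. Against the cyclopropyl and cyclopentyl groups, the result is an at least 1.9-fold lower number from compound 3 to compound 4 (0.28 log units; that floor lies within the scatter) and an at least 1.9-fold lower number from compound 1 to compound 4 (0.28 log units; that floor lies within the scatter), and each of these is only a floor, so neither step alone firmly separates compound 4 from the compounds with those rings: the limit of > 16000 nM in this assay, at which 2 of the 4 values shown sit.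

The compounds shown leave open whether an unsubstituted phenyl, a pyridine ring or a benzyl group on the same nitrogen would give a number in the same region as compound 2 and compound 4. They also leave open how far compound 1 and compound 3 truly lie from the two aromatic examples, as each of those two compounds is recorded only as a limit.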